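The source may hold more compounds than are shown below. What is called first, only, known or untested is meant among the compounds shown, and "the series" means these compounds.

Compound 2 `CC(C(=O)NCc1ccc(C(F)(F)F)nc1N1CCC(Cc2cc(F)cc(F)c2)CC1)c1ccc(NS(C)(=O)=O)c(F)c1` gives 0.4 nM in a functional assay on CHO-K1 cells for antagonist activity at transient receptor potential cation channel subfamily V member 1 (Homo sapiens), read by FLIPR; on this read-out higher numbers stand for weaker inhibition and lower numbers for stronger inhibition. Compound 1 `Cc1ccc(CC2CCN(c3nc(C(F)(F)F)ccc3CNC(=O)C(C)c3ccc(NS(C)(=O)=O)c(F)c3)CC2)cc1` gives 0.2 nM in this assay, and the step of a 2.0-fold higher number from compound 1 to compound 2 (0.30 log units; within the scatter) leaves the two level. Compound 3 `CCCCOC1CCN(c2nc(C(F)(F)F)ccc2CNC(=O)C(C)c2ccc(NS(C)(=O)=O)c(F)c2)CC1` carries butoxy in place of 3,5-difluorobenzyl on a saturated ring carbon. Among the measured compounds shown here, the only measured step, from compound 1 to compound 2, exchanges one aryl for another on the saturated chain carbon and keeps the aromatic ring; no measured step removes that ring or brings in a chain with an oxygen. The change in compound 3 is therefore without precedent here and is expected to weaken inhibition, a step of a 6.3-fold higher number from compound 2 to compound 3 (0.80 log units; beyond the scatter). For compound 3 the expected value is 2.5 nM, range 0.4 nM to 20 nM.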

Compound 3, inhibition constant: 3.5 nM
Beside the measured number, compound 3's estimate is 1.4-fold (0.15 log units) below it; the measured number falls inside the stated range.
By their numbers in this assay, from the lowest: compounds 1 and 2 (each within the scatter of the next); then compound 3.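

In this assay butoxy on a saturated ring carbon gives an 8.8-fold higher number from compound 2 to compound 3 (0.94 log units; beyond the scatter) in place of 3,5-difluorobenzyl and an 18-fold higher number from compound 1 to compound 3 (1.24 log units; beyond the scatter) in place of 4-methylbenzyl. Across these three compounds, this position tolerates one aryl exchanged for another, but inhibition weakens when the aromatic ring gives way to a ring-free chain bearing oxygen.

Still open, from the compounds shown here alone, is whether losing the ring or bringing in the oxygen accounts for the shift; a pentyl chain or a benzyloxy group on the same carbon would separate the two. No evidence at hand explains the result.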